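Dropping the Amino Group of Compound 3

A few compounds are considered here, and "the series" means these few. Any claim that something is new, unique, unknown or untested is made for them only; others in the source may bear on it.

Compound 1 `OCCOCn1c(Cl)nc2c(Cl)c(Cl)ccc21`: in a functional assay on KB cells (Homo sapiens) for inhibition (on this read-out lower numbers stand for stronger inhibition and higher numbers for weaker inhibition), compound 1 gives > 100000 nM, which is a limit of the assay rather than a number.
Compound 2 `OCCOCn1cnc2cc(Cl)c(Cl)cc21`: compound 2 gives > 100000 nM, again a limit.
Compound 3 `Nc1nc2c(Cl)cc(Cl)cc2n1COCCO`: compound 3 gives > 100000 nM, also a limit.

So far every value sits at the limit of > 100000 nM in this assay, at which 3 of the 3 values shown sit, and compound 3 stands there with the other two: no measurable inhibition has been seen for any of them. Compound 4 `OCCOCn1cnc2c(Cl)cc(Cl)cc21` differs from compound 3 by hydrogen in place of amino on an aromatic carbon. Within the data shown here, no step between measured compounds exists, so the size and direction of this change cannot be read from the data. The expectation is a flat step, nothing beyond the scatter, with a number no higher from compound 3 to compound 4 (the limit leaves the size open) as the expected change. Compound 4 is estimated at 100000 nM, between 30000 nM and 300000 nM, most likely reported once more only as a limit.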

Compound 4, half-maximal inhibitory concentration: > 100000 nM
Compound 4: no number, only a limit (the forecaster's own chance of this, stated with the estimate: 85%); the middle value lies on the limit itself.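

Among these compounds, compound 3 and compound 4 both give only a limit, and no step between them can be read. Left open is whether hydrogen in place of amino changes anything in this assay once inhibition becomes measurable on this core.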